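The compounds below may be only part of what the source reports. "The series", "measured", "known", "first", "only" and "open" are said of these compounds alone.

Working notes on the series. Compound 1 `O=C(NCc1ccc(S(=O)(=O)N2CCCCC2)cc1)c1cc2cnccc2s1` gives 15% in an ADME assay on microsomes from liver (Homo sapiens) for metabolic stability, read by LC-MS, with a stated time of 30 min, tested at 1 uM; on this read-out higher numbers stand for a more stable compound and lower numbers for a less stable compound. Compound 2 `O=C(NCc1ccc(S(=O)(=O)N2CCCCC2)cc1)c1ccn2cncc2c1` gives 54% in this assay and stands second highest of the three numbers; compound 3 `Cn1c(C(=O)NCc2ccc(S(=O)(=O)c3ccccc3)cc2)cc2ccncc21` gives 71% in this assay. Among the compounds with values here, the one measured change on the carbonyl carbon is the step of a number 39 percentage points higher from compound 1 to compound 2 (beyond the scatter), a large one. Compound 4 `O=C(NCc1ccc(S(=O)(=O)N2CCCCC2)cc1)c1cc2ccncc2[nH]1` is the next step from compound 2: a group of 9 heavy atoms (7 carbon, 2 nitrogen; one five-membered aromatic ring with 1 hetero atom, one six-membered aromatic ring with 1 hetero atom) in place of a group of 9 heavy atoms (7 carbon, 2 nitrogen; one five-membered aromatic ring with 2 hetero atoms, one six-membered aromatic ring with 1 hetero atom), on a carbonyl carbon. Within the data shown here, the same site has already moved the read-out by a number 39 percentage points higher from compound 1 to compound 2 (beyond the scatter), so a sizeable step is plausible, but no measured pair shows this swap, and the direction is open. Compound 4 is estimated at 45%, range 20% to 75%. The expected step is a number 9 percentage points lower from compound 2 to compound 4 (within the scatter).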

Compound 4, percent of the compound remaining: 50%
Compound 4: middle estimate off by 5 percentage points, on the low side, within the range that was stated.
By their numbers in this assay, from the lowest: compound 1; then compounds 4 and 2 (each within the scatter of the next); then compound 3.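

The swap on the carbonyl carbon gives a number 4 percentage points lower from compound 2 to compound 4 (within the scatter) in this assay, so the entering group, with its hydrogen-bond donor, and the leaving group cannot be told apart here. The same group gives a number 35 percentage points higher from compound 1 to compound 4 (beyond the scatter), so the large step from the sulfur-containing group in compound 1 is now seen with two different replacements. No available evidence bears on this result. Still open, on these data alone, is how a chloro group or a primary amine on the core of compound 4 would read out in this assay, and whether the hydrogen-bond donor matters at all.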